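Replacing the Methoxyphenyl Group on the Ring Nitrogen

This account rests on a few compounds, and the source may have more. Where it says the series, first, only, none or still open, it means among the compounds named here.

Compound 2 `COc1ccc(N2CCN(Cc3csc(N)c3C(=O)c3ccc(Cl)cc3)CC2)cc1` was tested in a functional assay on CHO cells with adenosine receptor A1 (Homo sapiens) as the target, read by cAMP accumulation and immunoassay, with a stated time of 6 min, tested at 0.01 uM (on this read-out lower numbers stand for a stronger effect and higher numbers for a weaker effect at the one concentration tested), where it gives -1.2%. Its number lies between the other two, though all three sit within the scatter of one another: compound 1 `Nc1scc(CN2CCN(c3cccc(Cl)c3Cl)CC2)c1C(=O)c1ccc(Cl)cc1` gives 1%, with a number 2.2 percentage points lower from compound 1 to compound 2 (within the scatter), and compound 3 `Nc1scc(CN2CCN(c3ccc(F)c(F)c3)CC2)c1C(=O)c1ccc(Cl)cc1` gives -3.2%, with a number 2 percentage points lower from compound 2 to compound 3 (within the scatter). Compound 4 `Nc1scc(CN2CCN(c3cccc(Cl)c3)CC2)c1C(=O)c1ccc(Cl)cc1` differs from compound 2 in one place: 3-chlorophenyl in place of 4-methoxyphenyl on an amine nitrogen in a ring. The remaining step among the measured compounds, a number 4.2 percentage points lower from compound 1 to compound 3 (within the scatter), likewise stays within the scatter, as do the two steps just given, so no shift beyond the scatter is expected in this assay. Compound 4 is therefore estimated at -1%, in the range -8% to 6%, meaning an expected step of a number 0.2 percentage points higher from compound 2 to compound 4 (within the scatter).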

Compound 4, a percentage reported as activity, at one concentration (the size of the read-out at that concentration, not a potency): -3.1%
Estimate against measurement, compound 4: 2.1 percentage points above; measured number inside the range.
By their numbers in this assay, from the lowest: compounds 3, 4, 2 and 1 (each within the scatter of the next).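

In this assay, 3-chlorophenyl in place of 4-methoxyphenyl leaves the read-out within the scatter (a number 1.9 percentage points lower from compound 2 to compound 4 (within the scatter)), as does 3-chlorophenyl in place of 3,4-difluorophenyl (a number 0.1 percentage points higher from compound 3 to compound 4 (within the scatter)). New here is the loss of a single chloro group, with hydrogen in its place, and this too stays within the scatter (a number 4.1 percentage points lower from compound 1 to compound 4 (within the scatter)). No measurement available here offers an explanation for these results. Still open is whether an amine or a carboxylic acid on this phenyl ring would shift the read-out beyond the scatter, and a single concentration gives no potency for any of these compounds.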